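The source may report more compounds than this note shows. Statements on the series, on what has been measured and on what is new or still open speak of the compounds shown alone.

Measured compounds:
compound 1 `NC(=O)N/N=C\c1cccc(Oc2ccccc2)c1` — in a physicochemical assay for lipophilicity (on this read-out lower numbers stand for lower lipophilicity and higher numbers for higher lipophilicity), compound 1 gives 2.07
compound 2 `NC(=O)N/N=C/c1ccc(Oc2ccccc2)cc1` — in this assay compound 2 gives 2.66

Compound 2 holds the highest of the two numbers in this assay; the nearest is compound 1, whose number is lower by a margin beyond the usual scatter. Compound 3 `NC(=O)N/N=C/c1ccc(Oc2ccc(Oc3ccccc3)cc2)cc1` differs from compound 2 by phenoxy in place of hydrogen on an aromatic carbon. Among the measured compounds shown here, no pair of measured compounds shows a step of this kind, so nothing measured here sets its size. The step in this assay is nonetheless expected to be large and upward, a number 1.74 log units higher from compound 2 to compound 3 (beyond the scatter). For compound 3 the estimate in this assay is 4.4, expected to fall between 3.8 and 5.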

Compound 3, partition coefficient: 1.92
Compound 3: the middle estimate sits 2.48 log units above what was measured; the whole stated range lies above it.
By their numbers in this assay, from the lowest: compounds 3 and 1 (each within the scatter of the next); then compound 2.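

Phenoxy in place of hydrogen on this aromatic carbon, para to a large group, gives a number 0.74 log units lower from compound 2 to compound 3 (beyond the scatter) in this assay, the first step at this position. A group of 7 heavy atoms therefore moves the number downward here, and this single pair sets the size and direction of the change. No available evidence accounts for that direction.

On these data alone, whether an amine, a carboxylic acid or a longer chain at this carbon would also lower the number remains open. So does the step that a smaller ether such as methoxy would give.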